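This account rests on a few compounds, and the source may have more. Where it says the series, first, only, none or still open, it means among the compounds named here.

In a functional assay on A2780 cells (Homo sapiens) for antiproliferative activity, read by MTT assay, with a stated time of 48 h (on this read-out lower numbers stand for stronger inhibition and higher numbers for weaker inhibition), compound 1 (`CCOc1ccc(-c2nc(NS(=O)(=O)c3ccc(OC)c(F)c3)sc2-c2cc(OC)c(OC)c(OC)c2)cc1`) gives > 5000 nM as a limit of the assay, not a number. Compound 2 (`CCOc1ccc(-c2nc(NS(=O)(=O)c3ccc(C)c(C)c3)sc2-c2cc(OC)c(OC)c(OC)c2)cc1`) gives > 5000 nM as a limit too, so it has no number of its own. Compound 3 (`C=CCN(CC=C)c1nc(-c2ccc(OCC)cc2)c(-c2cc(OC)c(OC)c(OC)c2)s1`) carries diallylamino in place of ((3,4-dimethylphenyl)sulfonyl)amino on an aromatic carbon, next to the ring nitrogen and next to the ring sulfur, and diallylamino in place of ((3,4-dimethylphenyl)sulfonyl)amino on an aromatic carbon is the whole difference. For the measured compounds named here, the one measured step, a step that the two limits leave unreadable from compound 1 to compound 2 with 3,4-dimethylphenyl in place of 3-fluoro-4-methoxyphenyl on a sulfonyl sulfur, has no readable size and so offers none to carry over. The evidence amounts to the limit of > 5000 nM in this assay, at which 2 of the 2 values shown sit, and nothing more, which leaves any expectation loose. A change of an at least 2.0-fold lower number from compound 2 to compound 3 (0.30 log units; that floor lies within the scatter) toward stronger inhibition is tentatively expected. For compound 3 the estimated value is 2500 nM with an expected range between 150 nM and 10000 nM on this read-out.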

Compound 3, half-maximal inhibitory concentration: > 5000 nM
Compound 3: no number, only a limit (the forecaster's own chance of this, stated with the estimate: 45%); at least 2.0-fold (0.30 log units) between middle value and limit.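

In this assay compound 3 gives > 5000 nM, a limit and not a number. For the compounds shown here, compound 2 also stands at a limit, so no step between compound 2 and compound 3 can be read. The compounds shown leave open how strongly any of the three inhibits, and whether either exchange changes activity at all.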